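The source may report more compounds than this note shows. Statements on the series, on what has been measured and on what is new or still open speak of the compounds shown alone.

Measured so far:
Compound 1 `COc1ccc(/C=C/C(=O)c2ccccc2-c2ccc(OC)c(OC)c2)cc1`: 320 nM
Compound 2 `COc1ccc(/C=C/C(=O)c2ccccc2-c2ccc(F)cc2)cc1`: 53 nM
Compound 3 `COc1ccc(OC)c(/C=C/C(=O)c2ccccc2-c2ccc(F)cc2)c1`: 750 nM

In a functional assay on CNE-2 cells (Homo sapiens) for antiproliferative activity, read by sulforhodamine B assay, with a stated time of 48 h (a higher number here means a weaker inhibitor, a lower number a stronger inhibitor), compound 2 stands as the strongest of the three at 53 nM, and the numbers for the other two lie beyond the scatter from it. Compound 4 `COc1ccc(/C=C/C(=O)c2ccccc2-c2ccc(F)cc2)cc1B(O)O` has not yet been measured. It departs from compound 2 by one change, (a group of 3 heavy atoms (1 boron, 2 oxygen; no ring) in place of a hydrogen atom, on an aromatic carbon), on an aromatic carbon, ortho to a methoxy group and meta to a large group.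

Among the measured compounds shown here, no measured pair isolates a change of this kind, so the expectation rests on thin evidence. The ring that carries one methoxy group in compound 2 carries two in compound 3, which reads 750 nM, and this suggests that the number may rise when this ring is altered. A moderate rise is therefore expected, beyond the scatter but short of the gap seen there. The estimated step is a 2.5-fold higher number from compound 2 to compound 4 (0.39 log units; beyond the scatter). For compound 4 the estimated value is 130 nM, with an expected range from 20 nM to 800 nM.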

Compound 4, half-maximal inhibitory concentration: 21 nM
Estimate against measurement, compound 4: 6.2-fold (0.79 log units) above, and the stated range covers the measured number.
By their numbers in this assay, from the lowest: compound 4; then compound 2; then compound 1; then compound 3.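

In this assay, among the compounds shown here, a group of 3 heavy atoms (1 boron, 2 oxygen; no ring) in place of a hydrogen atom, on an aromatic carbon ortho to a methoxy group and meta to a large group, brings a 2.5-fold lower number from compound 2 to compound 4 (0.40 log units; beyond the scatter), the first step that isolates a single change. This carbon therefore accepts a group of this size, and here the substitution gives a stronger inhibitor rather than a weaker one. Nothing shown bears on the reason for this gain.

The compounds shown leave open whether a carboxylic acid or an amine on this same carbon would lower the number as well, and so whether boron itself matters. They also leave open how this group would behave on another carbon of the ring.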